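A ring amide in place of a benzyl amide

A few compounds are considered here, and "the series" means these few. Any claim that something is new, unique, unknown or untested is made for them only; others in the source may bear on it.

Compound 1 `COc1ccc(C[C@@H](O)/C=C/C=C/C(=O)N2CCCCC2)cc1OC` gives 39500 nM
Compound 2 `COc1ccc(C[C@@H](O)/C=C/C=C/C(=O)NCc2ccc(Cl)cc2)cc1OC` gives 18100 nM

Both numbers come from a functional assay on MCF7 cells (Homo sapiens) for antiproliferative activity, read by sulforhodamine B assay, with a stated time of 48 h (on this read-out lower numbers stand for stronger inhibition and higher numbers for weaker inhibition), and compound 2 stands lowest of the two, which makes it the stronger inhibitor of this pair. The next compound to consider is compound 3 `COc1ccc(C[C@@H](O)/C=C/C=C/C(=O)N2CCN(C)CC2)cc1OC` which keeps the shared core and differs from compound 2 only on the carbonyl carbon: 4-methylpiperazin-1-yl in place of (4-chlorobenzyl)amino on a carbonyl carbon is the whole change.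

Among the compounds with values here, only one measured step bears on this change. It is a 2.2-fold lower number from compound 1 to compound 2 (0.34 log units; beyond the scatter) and it is modest. Compound 3 gives up the (4-chlorobenzyl)amino group that came in with that step, and its 4-methylpiperazin-1-yl group resembles the piperidin-1-yl group of compound 1 at 39500 nM in being a six-membered non-aromatic ring. The data do not show what the extra ring nitrogen and its methyl group do, so this comparison is only a rough guide. A partial or full reversal is therefore expected, with a 2.1-fold higher number from compound 2 to compound 3 (0.32 log units; beyond the scatter) as the estimated step, toward weaker inhibition in this assay and about as large as the measured one. The estimate for compound 3 is 38000 nM with an expected range from 15000 nM to 90000 nM on this read-out.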

Compound 3, half-maximal inhibitory concentration: 17100 nM
Compound 3: middle estimate off by 2.2-fold (0.35 log units), on the high side; the measured number falls inside the stated range.
By their numbers in this assay, from the lowest: compounds 3 and 2 (each within the scatter of the next); then compound 1.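

In this assay, the change on the carbonyl carbon gives a 1.1-fold lower number from compound 2 to compound 3 (0.02 log units; within the scatter) and so sets a 4-methylpiperazin-1-yl group level with the (4-chlorobenzyl)amino group, even though it brings no aromatic ring and no amide hydrogen. The other new comparison, between two six-membered non-aromatic rings on that same carbon, gives a 2.3-fold lower number from compound 1 to compound 3 (0.36 log units; beyond the scatter). That step is about the same size as a 2.2-fold lower number from compound 1 to compound 2 (0.34 log units; beyond the scatter). Compound 1 and compound 3 both have a ring amide, and compound 1 still has the higher number. No measurement here explains why these groups give the numbers they do.

The compounds shown leave open whether the extra ring nitrogen or its methyl group accounts for the difference between compound 1 and compound 3, which a plain piperazin-1-yl or a morpholin-4-yl group on the carbonyl carbon could help to separate. They also leave open what the chlorine contributes in compound 2, a question that a benzylamino group without chlorine would address.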